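The source may hold more compounds than are shown below. What is called first, only, known or untested is meant among the compounds shown, and "the series" means these compounds.

Measured compounds in a functional assay on CHO-K1 cells for antagonist activity at adenosine receptor A1 (Homo sapiens), read by a beta-galactosidase reporter and cAMP accumulation, with stated times of 15 min and 6 h; on this read-out higher numbers stand for weaker inhibition and lower numbers for stronger inhibition:
compound 1 `Cc1ccc(-c2nc(N)c3ccsc3n2)o1` gives 493 nM
compound 2 `Cc1ccc(-c2nc(N)c3cc(-c4ccccc4)sc3n2)o1` gives 520 nM
compound 3 `Cc1ccc(-c2nc(N)c3cc(CCc4ccccc4)sc3n2)o1` gives 2780 nM

Compound 3 holds the highest number of the three: the steps of a 5.6-fold higher number from compound 1 to compound 3 (0.75 log units; beyond the scatter) and a 5.3-fold higher number from compound 2 to compound 3 (0.73 log units; beyond the scatter) are both beyond the scatter, whereas a 1.1-fold higher number from compound 1 to compound 2 (0.02 log units; within the scatter) is within it. Compound 4 `Cc1ccc(-c2nc(N)c3cc(Cc4ccccc4F)sc3n2)o1` is not yet measured. It differs from compound 3 by 2-fluorophenyl in place of benzyl on a saturated chain carbon bound to an aromatic carbon; the same difference, cut one bond further out, reads phenethyl to 2-fluorobenzyl. Among the measured compounds shown here, no measured step covers a 2-fluorobenzyl group, so the estimate rests on compound 2 and compound 3 alone. Since a 5.3-fold higher number from compound 2 to compound 3 (0.73 log units; beyond the scatter) is modest and compound 4 carries a chain of intermediate length, compound 4 is expected to land between these two, with the step of a 2.1-fold lower number from compound 3 to compound 4 (0.33 log units; beyond the scatter) expected. The estimate for compound 4 is 1300 nM, range 550 nM to 3200 nM.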

Compound 4, inhibition constant: < 16 nM
Compound 4 gave a limit, no number; the forecaster's own chance of this, stated with the estimate: 3%; at least 81-fold (1.90 log units) between middle value and limit.
By their numbers in this assay, from the lowest: compounds 1 and 2 (each within the scatter of the next); then compound 3. At a limit, below all of these: compound 4.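

Compound 4 is reported as a limit, not a number: the limit of < 16 nM in this assay, at which 1 of the 4 values shown sits.

Substitution on this aromatic carbon can clearly lower the number, which neither phenyl nor phenethyl did: 2-fluorobenzyl gives an at least 30-fold lower number from compound 1 to compound 4 (1.48 log units; beyond the scatter) and an at least 32-fold lower number from compound 2 to compound 4 (1.51 log units; beyond the scatter). The change from phenethyl to 2-fluorobenzyl gives an at least 170-fold lower number from compound 3 to compound 4 (2.23 log units; beyond the scatter), so this one position spans a wide range of values.

From the compounds shown here alone, how a plain benzyl group compares stays open, so the shorter chain and the fluorine cannot be told apart. Going by these compounds, the full size of each step also stays open.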